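Chain Extension in a Thioether Chloromethyl Ketone Series

The source may report more compounds than this note shows. Statements on the series, on what has been measured and on what is new or still open speak of the compounds shown alone.

Measured so far:
compound 1, `CCCSC[C@H](NC(C)=O)C(=O)CCl`, in a functional assay on MOLT-3 cells (Homo sapiens) (on this read-out higher numbers stand for weaker inhibition and lower numbers for stronger inhibition), compound 1 gives 8000 nM
compound 2, `CCCCCCSC[C@H](NC(C)=O)C(=O)CCl`, in this assay compound 2 gives 700 nM

Compound 2 holds the lowest of the two numbers, with compound 1 the only other. For the measured compounds named here, the single step seen, an 11-fold lower number from compound 1 to compound 2 (1.06 log units; beyond the scatter), came with propyl in place of hydrogen three bonds along the chain from a sulfur. Compound 3, `CCCCCCCCCSC[C@H](NC(C)=O)C(=O)CCl`, carries propyl in place of hydrogen on a saturated chain carbon, six bonds along the chain from a sulfur. Going by the values given here, that earlier step is the only one bearing on this change, so a further lowering in this assay is expected, though likely a smaller one. Compound 3 is therefore estimated at 350 nM (range 80 nM to 1500 nM), a step of a 2.0-fold lower number from compound 2 to compound 3 (0.30 log units; within the scatter).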

Compound 3, half-maximal inhibitory concentration: 6700 nM
For compound 3 the middle estimate is 19-fold (1.28 log units) below the measured one, and the stated range ends below it.
By their numbers in this assay, from the lowest: compound 2; then compounds 3 and 1 (each within the scatter of the next).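

In this assay the gain from the first extension does not continue: propyl in place of hydrogen on a saturated chain carbon, six bonds along the chain from a sulfur, brings a 9.6-fold higher number from compound 2 to compound 3 (0.98 log units; beyond the scatter) and so reverses the direction of the earlier step. Hexyl in place of hydrogen, three bonds along the chain from a sulfur, shows only a 1.2-fold lower number from compound 1 to compound 3 (0.08 log units; within the scatter) and so the earlier gain is not kept. Nothing available here accounts for this reversal.

Still open, from the compounds shown here alone, is how a heptyl or an octyl chain would read, and whether an amine or a carboxylic acid at the end of the hexyl chain would keep the number of compound 2.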